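Swapping methyl for bromo in a small series

The source may report more compounds than this note shows. Statements on the series, on what has been measured and on what is new or still open speak of the compounds shown alone.

Measured in a functional assay on A549 cells (Homo sapiens) for inhibition, read by CCK-8 assay, with a stated time of 72 h, tested at 2 uM (a higher number here means more inhibition of growth at the concentration tested, a lower number less inhibition of growth), so far:
compound 1 `COc1ccc(SCc2ccc(C(=O)Nc3ccccc3N)cc2)cc1` gives 45.7%
compound 2 `Nc1ccccc1NC(=O)c1ccc(CSc2cccc(F)c2)cc1` gives 46.9%
compound 3 `Cc1ccc(SCc2ccc(C(=O)Nc3ccccc3N)cc2)cc1` gives 40.5%

Compound 3 cannot be told apart from the other two: the gaps a number 5.2 percentage points lower from compound 1 to compound 3 (within the scatter) and a number 6.4 percentage points lower from compound 2 to compound 3 (within the scatter) are both small. Compound 4 `Nc1ccccc1NC(=O)c1ccc(CSc2ccc(Br)cc2)cc1` carries bromo in place of methyl on an aromatic carbon, para to a large group (bromo in place of methyl on an aromatic carbon). Going by the values given here, no bromo compound has been measured yet. Among the compounds with values here, the closest guide is the first gap above, which is methyl in place of methoxy on an aromatic carbon. The exchange of aryl groups on sulfur in a number 1.2 percentage points higher from compound 1 to compound 2 (within the scatter) was small too. So in this assay no step beyond the scatter is expected. The step expected here (a number 3.5 percentage points higher from compound 3 to compound 4 (within the scatter)) stays modest. Compound 4 is estimated at 44% (expected range 33% to 55%).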

Compound 4, percent growth inhibition at one concentration: 33.2%
For compound 4 the middle estimate is 10.8 percentage points above the measured one; the range from low to high includes it.
By their numbers in this assay, from the lowest: compounds 4, 3, 1 and 2 (each within the scatter of the next, the first and the last beyond it).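

In this assay, bromo on this aromatic carbon, para to a large group, cannot be told apart from methyl (a number 7.3 percentage points lower from compound 3 to compound 4 (within the scatter)). Even so, compound 4 gives the first gaps in the series that lie beyond the scatter (a number 13.7 percentage points lower from compound 2 to compound 4 (beyond the scatter); a number 12.5 percentage points lower from compound 1 to compound 4 (beyond the scatter)), so exchanges at this end of the molecule can register in this assay. Nothing available explains these gaps. Still open, as far as these compounds go, is whether an amine or a carboxylic acid on the same carbon would separate clearly from methyl or bromo.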